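Replacing the oxocyclobutyl amide with an aminopyrimidine

The source may hold more compounds than are shown below. What is called first, only, known or untested is meant among the compounds shown, and "the series" means these compounds.

Going by the values given here, compound 3 `C[C@@H](Cn1ccc(-c2ccc(C#N)c(Cl)c2)n1)NC(=O)C1CC(=O)C1` gives 22500 nM in a functional assay on VCaP cells (Homo sapiens) for antiproliferative activity, read by CCK-8 assay, with a stated time of 6 days (a higher number here means a weaker inhibitor, a lower number a stronger inhibitor), the highest of the three numbers known. Compound 1 `CC(O)c1cccc(C(=O)N[C@@H](C)Cn2ccc(-c3ccc(C#N)c(Cl)c3)n2)c1` gives 900 nM and compound 2 `CC(O)c1ccc(C(=O)N[C@@H](C)Cn2ccc(-c3ccc(C#N)c(Cl)c3)n2)cc1` gives 910 nM in this assay, with a 1.0-fold higher number from compound 1 to compound 2 (0.00 log units; within the scatter). The steps of a 25-fold higher number from compound 1 to compound 3 (1.40 log units; beyond the scatter) and a 25-fold higher number from compound 2 to compound 3 (1.39 log units; beyond the scatter) show that the (3-oxocyclobutyl)carbonyl group carries a large penalty against either aryl amide. Compound 4 `Cc1ccnc(N[C@@H](C)Cn2ccc(-c3ccc(C#N)c(Cl)c3)n2)n1` is the next step: 4-methylpyrimidin-2-yl in place of (3-oxocyclobutyl)carbonyl on an amine nitrogen. Among the compounds with values here, this change reintroduces an aromatic ring, so a drop back toward the aryl compounds is expected, though the carbonyl is also lost and no measured pair covers that. The step of a 15-fold lower number from compound 3 to compound 4 (1.18 log units; beyond the scatter) is expected to be large. Compound 4 is therefore estimated at 1500 nM, with a range of 300 nM to 8000 nM.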

Compound 4, half-maximal inhibitory concentration: 850 nM
Compound 4: middle estimate off by 1.8-fold (0.25 log units), on the high side; measured number inside the range.
By their numbers in this assay, from the lowest: compounds 4, 1 and 2 (each within the scatter of the next); then compound 3.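

The step of a 26-fold lower number from compound 3 to compound 4 (1.42 log units; beyond the scatter) shows that this amine nitrogen accepts a group without a carbonyl: 4-methylpyrimidin-2-yl, with the same heavy-atom count as (3-oxocyclobutyl)carbonyl, removes the large penalty. In this assay compound 4 stands within the scatter of compounds 1 and 2, so an amide carbonyl is not needed for numbers at this level among these compounds. No measurement here bears on the cause of this step. Still open, from the compounds shown here alone, is what the methyl contributes, and whether a pyrimidin-2-yl carrying an amine or a methoxy group in its place holds this level.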